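The source may report more compounds than this note shows. Statements on the series, on what has been measured and on what is new or still open speak of the compounds shown alone.

Measured compounds in a functional assay on cells (T-cell, Homo sapiens) for inhibition; on this read-out lower numbers stand for stronger inhibition and higher numbers for weaker inhibition:

- compound 1 `COc1ccc(-c2cnc3nc(N)nc(N4CCN(c5cc(Cl)cc(Cl)c5)CC4)c3n2)cc1OC` — 3400 nM
- compound 2 `COc1ccc(-c2cnc3nc(N)nc(OC(C)C)c3n2)cc1` — > 10000 nM (a limit of the assay, not a number)
- compound 3 `CCOc1nc(N)nc2ncc(-c3ccc(C#N)cc3)nc12` — > 10000 nM (a limit of the assay, not a number)

Compound 1 is the only one of the three with a numeric half-maximal inhibitory concentration in this assay. Compound 2 gives only > 10000 nM, a limit. Compound 3 gives only > 10000 nM, also a limit. For the measured compounds named here, two of the three readings therefore sit at the limit of > 10000 nM in this assay, at which 2 of the 3 values shown sit, so compound 1 is the sole anchor for any comparison within the set. Going by the values given here, no pair of measured compounds differs in a single place, so no measured step is available to calibrate the effect of a change at the ring amine.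

Compound 4 `COc1ccc(-c2cnc3nc(N)nc(N4CCN(C(=O)NCc5ccc(F)cc5)CC4)c3n2)cc1OC` has not been measured. Relative to compound 1 the change is (4-fluorobenzyl)carbamoyl in place of 3,5-dichlorophenyl on an amine nitrogen in a ring. Among the compounds with values here, with no comparable measured step in hand, the expectation rests on compound 1 alone, and the exchange is a large one, so the uncertainty is wide. The step from compound 1 to compound 4 is expected to be a 1.8-fold higher number from compound 1 to compound 4 (0.25 log units; within the scatter), that is a modest weakening that may not exceed the scatter. Compound 4 is accordingly estimated at 6000 nM in this assay, with a range from 1500 nM to 25000 nM.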

Compound 4, half-maximal inhibitory concentration: 37 nM
Compound 4: middle estimate off by 160-fold (2.21 log units), on the high side; measured number outside the range, below it.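

In this assay, the group on the amine nitrogen of the six-membered non-aromatic ring is now shown to have a strong influence: (4-fluorobenzyl)carbamoyl in place of 3,5-dichlorophenyl gives a 92-fold lower number from compound 1 to compound 4 (1.96 log units; beyond the scatter), the first measured step in the series. Both groups carry a six-membered aromatic ring of carbon only, so the presence of such a ring on this nitrogen does not by itself set the level of inhibition in this pair. For the compounds shown here, compounds 1 and 4 are the only two with numeric readings, and the rest of the set offers no further step at this position: the limit of > 10000 nM in this assay, at which 2 of the 4 values shown sit.

The exchange alters the carbonyl, the amide hydrogen, the benzyl spacing and the halogen pattern together, so the step cannot be divided among these features. From the compounds shown here alone, a plain benzyl or a phenylcarbamoyl group on the same nitrogen would help separate them, and whether the same exchange holds on a different aryl group of the shared core remains open.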